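A chloro added to the anilide of compound 1

This account rests on a few compounds, and the source may have more. Where it says the series, first, only, none or still open, it means among the compounds named here.

Within the data shown here, compound 1 `COc1ccc2c(=O)c(/C=C/C(=O)Nc3ccccc3)coc2c1` is tested in a functional assay (QGY7701 cells, Homo sapiens) for inhibition, read by MTT assay, with a stated time of 48 h (on this read-out lower numbers stand for stronger inhibition and higher numbers for weaker inhibition), where compound 1 gives 14000 nM, the second highest of the three numbers so far. Compound 2 `COc1ccc2c(=O)c(/C=C/C(=O)Nc3ccccc3Cl)coc2c1` gives 23000 nM and compound 3 `COc1ccc2c(=O)c(/C=C/C(=O)NCc3ccc(F)cc3)coc2c1` gives 7960 nM in this assay. The step of a 1.6-fold higher number from compound 1 to compound 2 (0.22 log units; within the scatter) stays within the scatter, as does a 1.8-fold lower number from compound 1 to compound 3 (0.25 log units; within the scatter), while a 2.9-fold lower number from compound 2 to compound 3 (0.46 log units; beyond the scatter) is modest. Compound 4 `COc1ccc2c(=O)c(/C=C/C(=O)Nc3ccc(Cl)cc3)coc2c1` differs from compound 1 by chloro in place of hydrogen on an aromatic carbon. Among the measured compounds shown here, the only measured step of the same kind is a 1.6-fold higher number from compound 1 to compound 2 (0.22 log units; within the scatter), which did not leave the scatter, so no step beyond the scatter is expected for compound 4 in this assay. Compound 4 is therefore expected to give 14000 nM, within 6000 nM to 35000 nM, which means an expected step of no change at the digits printed from compound 1 to compound 4 (within the scatter).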

Compound 4, half-maximal inhibitory concentration: > 100000 nM
Compound 4 was reported as a limit; the forecaster's own chance of this, stated with the estimate: 5%; at least 7.1-fold (0.85 log units) between middle value and limit.
By their numbers in this assay, from the lowest: compounds 3, 1 and 2 (each within the scatter of the next, the first and the last beyond it). At a limit, above all of these: compound 4.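

Compound 4 is reported only as a limit: the limit of > 100000 nM in this assay, at which 1 of the 4 values shown sits. Chloro para to a large group gives an at least 7.1-fold higher number from compound 1 to compound 4 (0.85 log units; beyond the scatter), so at this place the change leaves the scatter, whereas the earlier chloro step, a 1.6-fold higher number from compound 1 to compound 2 (0.22 log units; within the scatter), did not. The gap also holds against the other two compounds, with an at least 4.3-fold higher number from compound 2 to compound 4 (0.63 log units; beyond the scatter) and an at least 12-fold higher number from compound 3 to compound 4 (1.09 log units; beyond the scatter).

Going by these compounds, whether an amine or a carboxylic acid in the same place would move the number as chloro does remains open. So does whether any group there could lower it.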